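Dialkylamino variation at the chloro-bearing core

This account rests on a few compounds, and the source may have more. Where it says the series, first, only, none or still open, it means among the compounds named here.

Compound 1 `CCN(c1nc(Cl)nc(N[C@@H](C)c2ccccc2)n1)C(C)C` gives 537 nM in an ADME assay on the whole organism for inhibition, with Oryza sativa as the target, with a stated time of 4 days; on this read-out higher numbers stand for weaker inhibition and lower numbers for stronger inhibition. Among the three numbers so far it stands second highest. Compound 2 `CCCN(CCC)c1nc(Cl)nc(N[C@@H](C)c2ccccc2)n1` gives 331 nM in this assay, and compound 3 `CCCCNc1nc(Cl)nc(N[C@@H](C)c2ccccc2)n1` gives 23400 nM. The step of a 1.6-fold lower number from compound 1 to compound 2 (0.21 log units; within the scatter) swaps one dialkylamino group for another and stays within the scatter. The steps of a 44-fold higher number from compound 1 to compound 3 (1.64 log units; beyond the scatter) and a 71-fold higher number from compound 2 to compound 3 (1.85 log units; beyond the scatter) both replace a dialkylamino group by butylamino and are large, so the pair of measured dialkylamino compounds sits close together while the butylamino compound sits far off.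

Compound 4 `CCCN(C)c1nc(Cl)nc(N[C@@H](C)c2ccccc2)n1` differs from compound 1 by methyl(propyl)amino in place of ethyl(isopropyl)amino on an aromatic carbon. The entering group is again a dialkylamino group, one heavy atom fewer than in compound 1, of the same kind as the groups of compound 1 and compound 2. The step that bears on it is the one within the scatter from compound 1 to compound 2; the large steps to compound 3 concern butylamino and are not of this kind. No step beyond the scatter is therefore expected in this assay. For compound 4 the estimated value is 600 nM, with a range from 250 nM to 1500 nM. This estimate means an expected step of a 1.1-fold higher number from compound 1 to compound 4 (0.05 log units; within the scatter), within the scatter.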

Compound 4, half-maximal inhibitory concentration: 5500 nM
Beside the measured number, compound 4's estimate is 9.2-fold (0.96 log units) below it; the whole stated range lies below it.
By their numbers in this assay, from the lowest: compounds 2 and 1 (each within the scatter of the next); then compound 4; then compound 3.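

In this assay a dialkylamino group as such does not keep the number low: a 10-fold higher number from compound 1 to compound 4 (1.01 log units; beyond the scatter) comes with methyl(propyl)amino, 5 heavy atoms, replacing ethyl(isopropyl)amino, 6 heavy atoms, at the position opposite the ring nitrogen. The step of a 17-fold higher number from compound 2 to compound 4 (1.22 log units; beyond the scatter) is also large and rests on hydrogen in place of ethyl on a saturated chain carbon bound to the nitrogen, so trimming one propyl chain to methyl is enough to leave the range shared by compound 1 and compound 2. The step of a 4.3-fold lower number from compound 3 to compound 4 (0.63 log units; beyond the scatter) still keeps the butylamino compound apart, so the three dialkylamino compounds no longer form one tight group and the series now spreads over three levels, with compound 4 in the middle.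

Open, on these data alone, is whether the rise follows the methyl group itself or the smaller count of heavy atoms, a question that dimethylamino, diethylamino or dibutylamino at this position would help to separate. Nothing at hand gives a measured account of what lies behind these steps.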